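The compounds below may be only part of what the source reports. "The series", "measured", "known", "first", "only" and "open" are said of these compounds alone.

Measured compounds:
- compound 1, `CN(C)CCN(CCN(C)C)c1ccc(C(=O)N2CCc3ccc(OS(N)(=O)=O)cc3C2)cc1`: 1.93
- compound 2, `NS(=O)(=O)Oc1ccc2c(c1)CN(C(=O)c1ccc(N(Cc3ccccc3)Cc3ccco3)cc1)CC2`: 1.93
- compound 3, `NS(=O)(=O)Oc1ccc2c(c1)CN(C(=O)c1ccc(N3CCC(N4CCCCC4)CC3)cc1)CC2`: 1.93

Of the compounds shown here, three sharing the core of compound 1 have been measured in a physicochemical assay for lipophilicity; on this read-out higher numbers stand for higher lipophilicity and lower numbers for lower lipophilicity. Compound 1 gives 1.93 in this assay, and compound 2 gives 1.93. Compound 3 gives 1.93. Compound 1 therefore stands level with compounds 2 and 3 at the digits shown; the nearest of them is compound 2 and the furthest is compound 3, and in both cases the gap lies within the scatter. Three different amino substituents on the same aromatic carbon thus return the same read-out here.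

Compound 4, `CCN(Cc1ccccn1)c1ccc(C(=O)N2CCc3ccc(OS(N)(=O)=O)cc3C2)cc1`, has not yet been measured. It differs from compound 1 in one place: ethyl((pyridin-2-yl)methyl)amino in place of bis(2-(dimethylamino)ethyl)amino on an aromatic carbon. Within the data shown here, no step between two measured compounds has been defined, so the size of the step from compound 1 to compound 4 is open. Because compound 1 sits at 1.93, compound 2 at 1.93 and compound 3 at 1.93 with very different groups in this position, compound 4 is expected to show a step no larger than the scatter, or only modestly upward, in this assay. For compound 4 the estimate is 2.1, with a range from 1.5 to 2.7, which is expected to mean a step of a number 0.17 log units higher from compound 1 to compound 4 (within the scatter).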

Compound 4, partition coefficient: 1.93
The estimate for compound 4 lay 0.17 log units above the measured number, and the stated range covers the measured number.
By their numbers in this assay, from the lowest: compounds 1, 2, 3 and 4 (each within the scatter of the next).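

Among these compounds, this is the first step at this position that can be read as a single exchange: in this assay, putting ethyl((pyridin-2-yl)methyl)amino in place of bis(2-(dimethylamino)ethyl)amino on the aromatic carbon gives no change at the digits printed from compound 1 to compound 4 (within the scatter). The change is not a trivial one on paper, since a group with no ring, 11 heavy atoms and 3 hydrogen-bond acceptors leaves, and a group with one six-membered aromatic ring, 10 heavy atoms and 2 hydrogen-bond acceptors enters, yet the read-out does not register it. No measurement at hand accounts for this constancy.

All four compounds carry an amino substituent at this place, so the compounds shown leave open whether a carboxylic acid, a methoxy group or a bare hydrogen on the same aromatic carbon would return the same read-out in this assay. They also leave open whether a group bearing a hydrogen-bond donor, such as a primary amine or a hydroxyl, would move the number beyond the scatter.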